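Swapping a ring for methoxy on a shared core

A few compounds are considered here, and "the series" means these few. Any claim that something is new, unique, unknown or untested is made for them only; others in the source may bear on it.

Measured in a functional assay on A549 cells (Homo sapiens) for inhibition, read by MTT assay, with a stated time of 72 h; a higher number here means a weaker inhibitor, a lower number a stronger inhibitor:
- compound 1 `Cc1ccc(-c2cc(C(=O)N3CCC4(CC3)CC(=O)c3nn(C(C)(C)C)cc3O4)c3ccccc3n2)cc1`: 5300 nM
- compound 2 `CC(C)(C)n1cc2c(n1)C(=O)CC1(CCN(C(=O)c3cc(-c4ccccc4Cl)nc4ccccc34)CC1)O2`: 2180 nM
- compound 3 `CC(C)(C)n1cc2c(n1)C(=O)CC1(CCN(C(=O)c3cc(-c4ccccn4)nc4ccccc34)CC1)O2`: 7720 nM

These three compounds share one core and differ only in the group on one aromatic carbon. Compound 3 reads 7720 nM. Its closest neighbour gives a 1.5-fold higher number from compound 1 to compound 3 (0.16 log units; within the scatter), so those two cannot be told apart. The other comparison gives a 3.5-fold higher number from compound 2 to compound 3 (0.55 log units; beyond the scatter).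

The next compound, compound 4 `COc1cc(C(=O)N2CCC3(CC2)CC(=O)c2nn(C(C)(C)C)cc2O3)c2ccccc2n1`, has not yet been measured. It carries methoxy in place of pyridin-2-yl on an aromatic carbon, next to the ring nitrogen (methoxy in place of pyridin-2-yl on an aromatic carbon).

Among the measured compounds shown here, the measured steps at this same carbon offer the only guide. The largest is a 3.5-fold higher number from compound 2 to compound 3 (0.55 log units; beyond the scatter), and the remaining one is a 2.4-fold lower number from compound 1 to compound 2 (0.39 log units; beyond the scatter). So swapping these groups has moved the number only moderately. However, each of those steps exchanges one ring for another, and none shows what happens when a ring gives way to a small group without a ring, so the guide is loose. In this assay, the expected change is therefore small, with no shift clearly beyond the scatter: the estimated step is a 1.2-fold higher number from compound 3 to compound 4 (0.07 log units; within the scatter). For compound 4 the estimated value is 9000 nM, with an expected range of 3500 nM to 25000 nM.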

Compound 4, half-maximal inhibitory concentration: > 10000 nM
Compound 4: a limit, no number; the forecaster's own chance of this, stated with the estimate: 15%; middle value at least 1.1-fold (0.04 log units) from the limit.
By their numbers in this assay, from the lowest: compound 2; then compounds 1 and 3 (each within the scatter of the next). At a limit, above all of these: compound 4.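

In this assay, compound 4 is recorded only as a limit, not as a number: the limit of > 10000 nM in this assay, at which 1 of the 4 values shown sits. Among the compounds shown here, it is the first compound here in which a group with no ring, methoxy, sits on this aromatic carbon, and the one clear result is an at least 4.5-fold higher number from compound 2 to compound 4 (0.66 log units; beyond the scatter), so 2-chlorophenyl gives a stronger inhibitor than methoxy at this position. The other two comparisons are less decisive, since an at least 1.2-fold higher number from compound 3 to compound 4 (0.11 log units; that floor lies within the scatter) and an at least 1.8-fold higher number from compound 1 to compound 4 (0.27 log units; that floor lies within the scatter) give only floors, and so methoxy cannot be firmly separated from pyridin-2-yl or 4-methylphenyl.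

As far as these compounds go, the true size of the change on going to methoxy remains unknown, as the limit sets only a floor on each step, and a single group with no ring cannot show whether losing the ring is what matters here. An amine or a longer chain such as ethoxy on the same carbon, or further substituted phenyl rings alongside 2-chlorophenyl, would be needed to show how far this position tolerates change.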